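Swapping the amide phenyl for a methoxybenzyl group

The source may report more compounds than this note shows. Statements on the series, on what has been measured and on what is new or still open speak of the compounds shown alone.

Compound 1 `COc1ccc2c(=O)c(/C=C/C(=O)Nc3ccccc3)coc2c1` is tested in a functional assay on Huh-7 cells (Homo sapiens) for inhibition, read by MTT assay, with a stated time of 48 h (a higher number here means a weaker inhibitor, a lower number a stronger inhibitor), where compound 1 gives 9050 nM. For the measured compounds named here, its only measured neighbour, compound 2 `COc1ccc2c(=O)c(/C=C/C(=O)NCc3cccc(F)c3)coc2c1`, gives 10100 nM in this assay; the two sit level, since a 1.1-fold higher number from compound 1 to compound 2 (0.05 log units; within the scatter). Compound 3 `COc1ccc(CNC(=O)/C=C/c2coc3cc(OC)ccc3c2=O)cc1` is not yet measured. It differs from compound 1 by 4-methoxybenzyl in place of phenyl on an amide-type nitrogen. Going by the values given here, the one step that bears on this, the move from compound 1 to compound 2, also put a benzyl-type group in place of phenyl and stayed within the scatter, so compound 3 is expected to shift little: a 1.1-fold higher number from compound 1 to compound 3 (0.04 log units; within the scatter). Compound 3 is therefore estimated at 10000 nM, with a range from 4500 nM to 22000 nM.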

Compound 3, half-maximal inhibitory concentration: 7570 nM
For compound 3 the middle estimate is 1.3-fold (0.12 log units) above the measured one; measured number inside the range.
By their numbers in this assay, from the lowest: compounds 3, 1 and 2 (each within the scatter of the next).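

In this assay, putting 4-methoxybenzyl on the amide-type nitrogen leaves the number level (a 1.2-fold lower number from compound 1 to compound 3 (0.08 log units; within the scatter)), and so does exchanging 3-fluorophenyl for 4-methoxyphenyl on the saturated chain carbon (a 1.3-fold lower number from compound 2 to compound 3 (0.13 log units; within the scatter)). This position therefore takes a benzyl-type group carrying an oxygen-containing methoxy group as readily as one carrying fluorine, at least across compound 1, compound 2 and compound 3. No measurement at hand speaks to why these three compounds sit level. As far as these compounds go, whether a longer chain carrying the ring, or an amine or a carboxylic acid on it, would move the number beyond the scatter stays open.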